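This account rests on a few compounds, and the source may have more. Where it says the series, first, only, none or still open, it means among the compounds named here.

Measured so far in a functional assay on HeLa cells (Homo sapiens) for inhibition, read by sulforhodamine B assay; a lower number here means a stronger inhibitor, a higher number a weaker inhibitor:
compound 1 `O=C1C(Nc2ccccc2F)=CC(=O)c2c1nc1n2[C@H]2OC[C@@H](O)[C@H]2OC1` gives 9820 nM;
compound 2 `CCc1ccc(NC2=CC(=O)c3nc4n(c3C2=O)[C@H]2OC[C@@H](O)[C@H]2OC4)cc1` gives 3990 nM.

Compound 1 has the higher of these two numbers, so it is the weaker inhibitor of the pair, and its gap to compound 2 lies beyond the usual scatter. Compound 3 `O=C1C(Nc2cccc(Cl)c2)=CC(=O)c2c1nc1n2[C@H]2OC[C@@H](O)[C@H]2OC1` has not yet been measured. It differs from compound 1 in one place: 3-chlorophenyl in place of 2-fluorophenyl on an amine nitrogen. Within the data shown here, no step between measured compounds shows what such a change does, so the expectation rests on compound 1 alone; a small step, perhaps toward a lower number, or none beyond the scatter, seems most likely. The expected step of a 1.6-fold lower number from compound 1 to compound 3 (0.21 log units; within the scatter) is modest. Compound 3 is estimated at 6000 nM, within 2500 nM to 15000 nM.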

Compound 3, half-maximal inhibitory concentration: 7970 nM
Estimate against measurement, compound 3: 1.3-fold (0.12 log units) below; measured number inside the range.
By their numbers in this assay, from the lowest: compounds 2, 3 and 1 (each within the scatter of the next, the first and the last beyond it).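

In this assay, placing 3-chlorophenyl where compound 1 has 2-fluorophenyl on the amine nitrogen gives a 1.2-fold lower number from compound 1 to compound 3 (0.09 log units; within the scatter), so this position accepts this exchange of one halogen-bearing phenyl group for another with no clear change in the reading. No measurement here accounts for this result.

On these data alone, the halogen and its place on the ring change together, so the effect of each alone remains unknown, and the two could even offset each other. Also open, as far as these compounds go, is what a cyclohexyl group, or a phenyl group carrying a methoxy group or an amine, would do at this nitrogen.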